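The compounds below may be only part of what the source reports. "The series", "measured", "known", "first", "only" and "open" are said of these compounds alone.

Three close relatives have been measured in a functional assay on M14 cells (Homo sapiens) for cytotoxicity, read by sulforhodamine B assay, with a stated time of 48 h; on this read-out higher numbers stand for weaker inhibition of growth and lower numbers for stronger inhibition of growth. Compound 1 `Nc1nc(Cl)c2ncn(Cc3ccc(CCl)cc3)c2n1` gives 38000 nM, compound 2 `ClCc1cccc(Cn2cnc3c(Cl)nc(Cl)nc32)c1` gives 3380 nM, and compound 3 `ClCc1ccc(Cn2cnc3c(Cl)nc(Cl)nc32)cc1` gives 24000 nM. Compound 2 stands lowest of the three, and its gaps to compound 3 and to compound 1 are both beyond the usual scatter. Compound 2 and compound 3 are built from the same atoms joined differently; the difference between the two cores is not broken down here.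

From compound 3 to compound 1 one group is swapped: amino in place of chloro on an aromatic carbon. That step was a 1.6-fold higher number from compound 3 to compound 1 (0.20 log units; within the scatter), so the swap left the number essentially where it was.

Compound 4 `Nc1nc(Cl)c2ncn(Cc3cccc(CCl)c3)c2n1` has not yet been measured. Within the data shown here, it arises from compound 2 by amino in place of chloro on an aromatic carbon, the same change, made at the same place, as the one from compound 3 to compound 1. Because the earlier swap gave only a 1.6-fold higher number from compound 3 to compound 1 (0.20 log units; within the scatter), a step of about the same small size is expected here too, namely a 1.6-fold higher number from compound 2 to compound 4 (0.20 log units; within the scatter). On that basis, compound 4 is expected to give about 5400 nM in this assay, most likely between 2500 nM and 12000 nM.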

Compound 4, concentration for total growth inhibition: 11700 nM
Compound 4: the middle estimate sits 2.2-fold (0.34 log units) below what was measured; low and high end bracket the measured number.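

In this assay, amino in place of chloro on an aromatic carbon gave a 3.5-fold higher number from compound 2 to compound 4 (0.54 log units; beyond the scatter). Set beside the same swap on the other core, this step cannot be told apart from the earlier one: the same change on two cores in this assay, a 1.6-fold higher number (0.20 log units; within the scatter) from compound 3 to compound 1 and a 3.5-fold higher number (0.54 log units; beyond the scatter) from compound 2 to compound 4, 2.2-fold (0.34 log units) apart, within the scatter of two such steps. Among these compounds, the swap thus carries from one core to the other with no detectable difference in step size, but this rests on only two pairs, and only the step on compound 2 stands clear of the scatter, so it does not show that the swap would weaken growth inhibition on every core, nor does it explain the result.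

The compounds shown leave open whether a different group in the same place, such as a methylamino, methoxy or hydroxyl group, would behave like amino. Also open, on these data alone, is what happens on either core when the chloromethyl group gives way to a plain methyl or a hydroxymethyl group.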